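A few compounds are considered here, and "the series" means these few. Any claim that something is new, unique, unknown or untested is made for them only; others in the source may bear on it.

Going by the values given here, compound 2 `Nc1ccccc1NC(=O)c1ccc(CSC(=S)N2CCN(C3CCCCC3)CC2)cc1` stands highest of the two numbers so far: in a functional assay on A-375 cells (Homo sapiens) for antiproliferative activity, read by CCK-8 assay, with a stated time of 72 h, tested at 8 uM (a higher number here means a stronger effect of the compound at the concentration tested, a lower number a weaker effect), compound 2 gives 89.9%. Among the compounds with values here, compound 1 `N#Cc1ccc(N2CCN(C(=S)SCc3ccc(C(=O)Nc4ccccc4N)cc3)CC2)cc1` is the only other member; in this assay compound 1 gives 62.9%, and the step of a number 27 percentage points higher from compound 1 to compound 2 (beyond the scatter) is the one measured change at this ring nitrogen. Compound 3 `Nc1ccccc1NC(=O)c1ccc(CSC(=S)N2CCN(Cc3ccccc3)CC2)cc1` differs from compound 2 by benzyl in place of cyclohexyl on an amine nitrogen in a ring. Within the data shown here, the single step that bears on this is a number 27 percentage points higher from compound 1 to compound 2 (beyond the scatter), where an aromatic group on the ring nitrogen gave way to cyclohexyl and the number rose. Compound 3 moves back toward an aromatic group, though benzyl is not the 4-cyanophenyl of compound 1, so a full return is not assumed. The expected move is a modest decrease, a number 11.9 percentage points lower from compound 2 to compound 3 (beyond the scatter), with a fair chance that it stays within the scatter. The estimate for compound 3 in this assay is 78%, with a range from 55% to 95%.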

Compound 3, a percentage reported as inhibition, at one concentration (the size of the read-out at that concentration, not a potency): 29.3%
Compound 3: the middle estimate sits 48.7 percentage points above what was measured, and the stated range ends above it.
By their numbers in this assay, from the lowest: compound 3; then compound 1; then compound 2.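

Benzyl in place of cyclohexyl on the amine nitrogen in the ring gives a number 60.6 percentage points lower from compound 2 to compound 3 (beyond the scatter) in this assay, and benzyl in place of 4-cyanophenyl gives a number 33.6 percentage points lower from compound 1 to compound 3 (beyond the scatter). Benzyl therefore stands below both other groups at this position, while compound 1 and compound 3, both carrying an aromatic ring of carbon, lie far apart, so the presence of such a ring alone does not set the number. No supporting measurement bears on the cause of these gaps.

Whether the low number follows the methylene link or benzyl as a whole remains open, with only three groups shown at this nitrogen. Plain phenyl, cyclohexylmethyl and the longer phenethyl chain would help separate these readings.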